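A few compounds are considered here, and "the series" means these few. Any claim that something is new, unique, unknown or untested is made for them only; others in the source may bear on it.

Compound 2 `C=CCn1ncc2c(C)nc(Cc3ccccc3)n2c1=O` is the starting point of this step. In a functional assay for inhibition, with Homo sapiens as the target (on this read-out lower numbers stand for stronger inhibition and higher numbers for weaker inhibition), compound 2 gives > 48000 nM, which is a limit of the assay rather than a number. Compound 1 `C=CCn1ncc2c(Br)nc(Cc3ccccc3)n2c1=O` differs from it at one place; in this assay compound 1 gives > 48000 nM, again a limit. The step that the two limits leave unreadable from compound 1 to compound 2 is therefore not readable, since the limit of > 48000 nM in this assay, at which 3 of the 3 values shown sit, holds for both. Compound 3 `Cc1nc(-c2ccccc2)n2c(O)nncc12` is a further member of the series; in this assay compound 3 gives > 48000 nM, once more a limit.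

Compound 4 `C=CCn1ncc2c(C)nc(C(C)(C)C)n2c1=O` has not been measured. It differs from compound 2 in this way: tert-butyl in place of benzyl on an aromatic carbon. For the measured compounds named here, no measured step bears on an exchange of benzyl for tert-butyl, and the only step in hand is unreadable, because the limit of > 48000 nM in this assay, at which 3 of the 3 values shown sit, is where every value sits. For compound 4 the step that the limit leaves unreadable from compound 2 to compound 4 is expected to be none beyond the scatter. In this assay compound 4 is thus estimated at 100000 nM, with a range from 30000 nM to 500000 nM, most likely reported as a limit again.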

Compound 4, half-maximal inhibitory concentration: > 48000 nM
Compound 4 ended at the assay's limit (the forecaster's own chance of this, stated with the estimate: 85%); the middle value lies beyond the limit too.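

No step can be read between compound 2 and compound 4, which both stop at a limit and not at a number: the limit of > 48000 nM in this assay, at which 4 of the 4 values shown sit.

The compounds shown leave open which change to the shared core, if any, would give a measurable value in this assay.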